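The source may hold more compounds than are shown below. What is called first, only, known or untested is meant among the compounds shown, and "the series" means these compounds.

Of the compounds shown here, three with a shared core have been tested in an ADME assay on WI-38 cells (Homo sapiens) for cytotoxicity, read by MTT assay, with a stated time of 72 h; a lower number here means a stronger inhibitor, a higher number a weaker inhibitor. Compound 1 `O=C(CCc1cccc2c1B(O)OC2)NCc1ccccc1` gives > 100000 nM, which is a limit of the assay and not a number. Compound 2 `C#Cc1cccc(NC(=O)CCc2cccc3c2B(O)OC3)c1` gives > 100000 nM, also a limit. That places compound 2 at the limit of > 100000 nM in this assay, at which 2 of the 3 values shown sit. Compound 3 `C#Cc1ccccc1NC(=O)CCc1cccc2c1B(O)OC2` gives a true number, 18000 nM. Compound 4 `COc1ccc(-c2cccc(NC(=O)CCc3cccc4c3B(O)OC4)c2)cc1` has 4-methoxyphenyl in place of ethynyl on an aromatic carbon, meta to a large group: 4-methoxyphenyl in place of ethynyl on an aromatic carbon. For the measured compounds named here, no measured pair shows a change of this kind, so the forecast is loose. The value of compound 3, 18000 nM, shows that this core can give a measurable number. The expected change is an at least 1.6-fold lower number from compound 2 to compound 4 (0.22 log units; that floor lies within the scatter), a small move towards stronger inhibition that may stay hidden behind the limit. Compound 4 is estimated at 60000 nM, with an expected range of 20000 nM to 100000 nM.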

Compound 4, half-maximal inhibitory concentration: 1400 nM
Compound 4: the middle estimate sits 43-fold (1.63 log units) above what was measured, outside the stated range (below it).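

Putting 4-methoxyphenyl in place of ethynyl on this aromatic carbon, meta to a large group, gives an at least 71-fold lower number from compound 2 to compound 4 (1.85 log units; beyond the scatter) in this assay. For the compounds shown here, this position therefore has a strong influence on the reading in this assay, which the earlier compounds could not show. Compound 2 gives only a limit, so the step is a floor and its true size stays unknown: the limit of > 100000 nM in this assay, at which 2 of the 4 values shown sit.

The compounds shown do not separate the effect of the added ring from that of its methoxy group. Plain phenyl, or a phenyl carrying an amine instead, would be needed to tell them apart.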